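Series notes: isobutyl for benzyl on the shared core

A few compounds are considered here, and "the series" means these few. Any claim that something is new, unique, unknown or untested is made for them only; others in the source may bear on it.

compound 1 `O[C@@H]1[C@@H](OCc2ccccc2)[C@H](OCc2ccccc2)[C@@H](COCc2ccccc2)O[C@@H]1Cc1ccccc1` — a functional assay on HL-60 cells (Homo sapiens) for antiproliferative activity, read by MTT assay; a higher number here means a weaker inhibitor, a lower number a stronger inhibitor: "not active" (no number reported)
compound 2 `O[C@@H]1[C@@H](OCc2ccccc2)[C@H](OCc2ccccc2)[C@@H](COCc2ccccc2)O[C@H]1Cc1ccccc1` — this assay: 8700 nM

Compound 1 stands without a number in this assay: it is reported as not active, while compound 2 gives 8700 nM. Going by the values given here, the two are set apart only by the fact that compounds 1 and 2 differ only in the configuration as drawn, so no measured step touches the change considered here.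

Compound 3 `CC(C)C[C@H]1O[C@H](COCc2ccccc2)[C@@H](OCc2ccccc2)[C@H](OCc2ccccc2)[C@H]1O` differs from compound 1 by isopropyl in place of phenyl on a saturated chain carbon bound to a saturated ring carbon. Nothing measured here shows how this change acts, so no step size can be read off; the expectation rests on compound 1 alone. Compound 3 is expected to remain weak, with an estimated value of 30000 nM in a range from 5000 nM to 150000 nM, and a fair chance that only a limit is reported.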

Compound 3, half-maximal inhibitory concentration: 13900 nM
Estimate against measurement, compound 3: 2.2-fold (0.33 log units) above; the measured number falls inside the stated range.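

Compound 1 carries no number in this assay and compound 3 gives 13900 nM, so no step can be read between them. The compounds shown leave open what benzyl to isobutyl does in the configuration of compound 2.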